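Swapping nitro for fluoro on a shared core

A few compounds are considered here, and "the series" means these few. Any claim that something is new, unique, unknown or untested is made for them only; others in the source may bear on it.

Four compounds share one core and differ only in the group on one aromatic carbon of the six-membered ring and in the small chain on the other ring. Compound 1 `CCn1c(/C=C2/C(=O)Nc3ccc(C)cc32)nc2ccccc21` gives 39400 nM in a functional assay on 4T1 cells (Homo sapiens) for cytotoxicity, read by MTT assay, with a stated time of 48 h; a higher number here means a weaker inhibitor, a lower number a stronger inhibitor. Compound 3 `CC(C)n1c(/C=C2/C(=O)Nc3ccc(Cl)cc32)nc2ccccc21` gives 35700 nM in this assay; these two numbers lie within the usual scatter of each other. Compound 2 `Cn1c(/C=C2/C(=O)Nc3ccc([N+](=O)[O-])cc32)nc2ccccc21` carries a nitro group, and in this assay compound 2 gives > 50000 nM, which is a limit of the assay and not a number. Compound 2 thus sits at the limit of > 50000 nM in this assay, at which 1 of the 3 values shown sits.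

Compound 4 `Cn1c(/C=C2/C(=O)Nc3ccc(F)cc32)nc2ccccc21` has not yet been measured. It differs from compound 2 in one place: fluoro in place of nitro on an aromatic carbon. No measured pair of these compounds differs in a single place, so no measured step is known. Compound 2 offers only a limit. The step to compound 4 cannot be set against the scatter; the expectation is a move toward a stronger inhibitor, of a size that cannot be judged, with compound 4 landing near the numbers of compound 1 and compound 3. Compound 4 is expected to give 40000 nM in this assay, within 20000 nM to 80000 nM. This estimate amounts to an expected step of an at least 1.2-fold lower number from compound 2 to compound 4 (0.09 log units; that floor lies within the scatter).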

Compound 4, half-maximal inhibitory concentration: 29600 nM
The estimate for compound 4 lay 1.4-fold (0.13 log units) above the measured number; measured number inside the range.
By their numbers in this assay, from the lowest: compounds 4, 3 and 1 (each within the scatter of the next). At a limit, above all of these: compound 2.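

Fluoro in place of nitro on this aromatic carbon is the first change here that alters a single place, and in this assay it gives an at least 1.6-fold lower number from compound 2 to compound 4 (0.22 log units; that floor lies within the scatter). With fluoro on this carbon, the shared core and its small chain give a true number that later changes can be compared with, something the nitro group did not provide. The real size of the step stays unknown, and it may or may not exceed the usual scatter, because compound 2 stands at a limit of the assay and not at a number: the limit of > 50000 nM in this assay, at which 1 of the 4 values shown sits.

Compound 1 and compound 3 each differ from compound 4 in two places, so no further step can be read, and the effect of the chain on the other ring cannot be separated from that of the group on the aromatic carbon. Also open, from the compounds shown here alone, is how an amine or a carboxylic acid on this aromatic carbon, or a longer chain on the other ring, would fare in this assay.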